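Swapping Cyclohexyl for Benzyl on a Ring Nitrogen

The compounds below may be only part of what the source reports. "The series", "measured", "known", "first", "only" and "open" are said of these compounds alone.

Compound 1 `O=Cc1ccc(-c2cn3ccnc3c(-c3ccc4ncn(C5CCCCC5)c4c3)n2)cc1` and compound 2 `O=Cc1ccc(-c2cn3ccnc3c(-c3ccc4ncn(Cc5ccccc5)c4c3)n2)cc1` share one core and differ only in one place: benzyl in place of cyclohexyl on an aromatic nitrogen. In a functional assay on NCI-H23 cells (Homo sapiens) for inhibition, read by sulforhodamine B assay, with a stated time of 48 h, tested at 10 uM (a lower number here means less inhibition, a higher number more inhibition at the concentration tested (going by the name of the read-out)), compound 1 gives 54.5%, and compound 2 gives 54.5%. The step between them, no change at the digits printed from compound 1 to compound 2 (within the scatter), shows that this swap left the read-out where it was. Compound 3 `c1cn2cc(-c3ccc4c(c3)ncn4C3CCCCC3)nc(-c3ccc4ncn(C5CCCCC5)c4c3)c2n1` is built on a different core; how the two cores differ is not broken down here. In this assay compound 3 gives 20.5%, the lowest of the three measured numbers and beyond the usual scatter from both compound 1 and compound 2. Compound 4 `c1ccc(Cn2cnc3ccc(-c4nc(-c5ccc6c(c5)ncn6C5CCCCC5)cn5ccnc45)cc32)cc1` has not yet been measured. It differs from compound 3 by benzyl in place of cyclohexyl on an aromatic nitrogen, the same change as from compound 1 to compound 2, made at a place described in the same words. Because the earlier swap gave no change at the digits printed from compound 1 to compound 2 (within the scatter), the step for compound 4 is expected to be small, a number 0.5 percentage points higher from compound 3 to compound 4 (within the scatter). Compound 4 is therefore estimated to give 21% in this assay, most likely between 6% and 40%.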

Compound 4, a percentage reported as inhibition, at one concentration (the size of the read-out at that concentration, not a potency): -22.8%
Estimate against measurement, compound 4: 43.8 percentage points above; the whole stated range lies above it.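

In this assay, the swap of cyclohexyl for benzyl on an aromatic nitrogen did not behave the same way on the two cores: the same change on two cores in this assay, no change at the digits printed (within the scatter) from compound 1 to compound 2 and a number 43.3 percentage points lower (beyond the scatter) from compound 3 to compound 4, 43.3 percentage points apart, beyond the scatter of two such steps. On the core of compound 3, the swap gave a number 43.3 percentage points lower from compound 3 to compound 4 (beyond the scatter), so the near absence of a step on the core of compound 1 is no safe guide to the size of the step on this other core. Going by these compounds alone, with only one pair of compounds on each core, the results do not show why the two steps differ, or whether the same gap would appear with other groups, at another concentration or in another cell line.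

The compounds shown leave open how the two cores would respond to other groups on the same ring nitrogen, such as a methyl, a longer chain or a chain ending in an amine. They also leave open which part of the difference between the cores goes with the different outcome of the swap.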